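Alkylidene lactone series: geometric isomer of compound 1

The compounds below may be only part of what the source reports. "The series", "measured", "known", "first", "only" and "open" are said of these compounds alone.

Compound 1 `CC(C)CC(=O)OCC1(CO)C/C(=C/CC(C(C)C)C(C)C)C(=O)O1` and compound 2 `CC(C)C/C=C1\CC(CO)(COC(=O)CC(C(C)C)C(C)C)OC1=O` share a common core with the same substituents. In a physicochemical assay for lipophilicity (on this read-out lower numbers stand for lower lipophilicity and higher numbers for higher lipophilicity), compound 1 gives 4.1, and compound 2 gives 4.1, so compound 1 stands level with compound 2 at the digits shown, within the scatter. Compound 3 `CC(C)CC(=O)OCC1(CO)C/C(=C\CC(C(C)C)C(C)C)C(=O)O1` is not yet measured; it differs from compound 1 as follows: the two compounds have the same atoms and bonds; at least one stereo element is drawn with a configuration in one of them and without one in the other: 1 of 2 stereo elements differ; a double bond is drawn Z in compound 1 and E in compound 3. Among the compounds with values here, no measured pair shows such a step, so in this assay a step within the scatter is expected, in no set direction. Compound 3 is expected to give 4.1, in the range 3.8 to 4.4. The expected step of no change at the digits printed from compound 1 to compound 3 (within the scatter) is estimated to stay within the scatter.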

Compound 3, partition coefficient: 4.1
For compound 3 middle estimate and measured number coincide at the digits printed; measured number inside the range.
By their numbers in this assay, from the lowest: compounds 1, 2 and 3 (each within the scatter of the next).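

In this assay, turning the double bond from Z to E gives no change at the digits printed from compound 1 to compound 3 (within the scatter). Within the data shown here, this is the first step that touches double-bond geometry alone, and at this position the read-out does not separate the two drawn forms. One caution applies to this reading: the fact that one of compounds 1 and 3 is drawn with a defined configuration and the other without, at the place where they differ.

The compounds shown leave open whether the geometry change stays within the scatter when the shared core carries an amine or a carboxylic acid. They also leave open whether a longer chain on the double bond alters this.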